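A few compounds are considered here, and "the series" means these few. Any claim that something is new, unique, unknown or untested is made for them only; others in the source may bear on it.

Compound 1 `CC1=CC[C@H]2[C@@H]1CC=C(C)[C@@H](CCC1=C(C)CC[C@@H]3OC(C)(C)[C@@H](O)CC[C@@]13C)C2(C)C` opens the set. In a functional assay on MDA-MB-231 cells (Homo sapiens) for antiproliferative activity, read by MTT assay, with a stated time of 72 h (on this read-out lower numbers stand for stronger inhibition and higher numbers for weaker inhibition), compound 1 gives only a limit, > 50000 nM. Among the compounds with values here, compound 2 `CC1=CC[C@H]2[C@H](CC[C@]2(C)O)C(C)(C)[C@@H]1CC[C@H]1[C@]2(C)CC[C@H](OC(=O)c3ccc(C)cc3)C(C)(C)O[C@H]2CC[C@@]1(C)O` in this assay gives 33400 nM, the single plain number so far; the other value recorded is the limit of > 50000 nM in this assay, at which 1 of the 2 values shown sits. Compound 3 `CC1=CC[C@H]2[C@H](CC[C@]2(C)O)C(C)(C)[C@@H]1CC[C@H]1[C@]2(C)CC[C@H](OC(=O)c3ccccc3Cl)C(C)(C)O[C@H]2CC[C@@]1(C)O` differs from compound 2 in one place: 2-chlorophenyl in place of 4-methylphenyl on a carbonyl carbon. Within the data shown here, no pair of measured compounds differing in one place exists, so nothing shows how large such a change usually is. The step from compound 2 to compound 3 in this assay is expected to be a 1.1-fold lower number from compound 2 to compound 3 (0.05 log units; within the scatter), not beyond the usual scatter. Compound 3 is therefore estimated at 30000 nM, between 12000 nM and 75000 nM.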

Compound 3, half-maximal inhibitory concentration: 24300 nM
Estimate against measurement, compound 3: 1.2-fold (0.09 log units) above, within the range that was stated.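

In this assay, putting 2-chlorophenyl in place of 4-methylphenyl on a carbonyl carbon gives a 1.4-fold lower number from compound 2 to compound 3 (0.14 log units; within the scatter). Within the data shown here, this is the first step measured in the set, and it shows that exchanging these two aromatic groups at this position produces no change that can be told apart from the normal variation between repeated measurements. Nothing measured here explains this result. From the compounds shown here alone, it remains open whether an amine or a longer chain in place of the aromatic ring on this carbonyl carbon would shift the read-out beyond that variation.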